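Swapping the 2-methylphenyl of compound 2 for a dimethyl-oxazolyl

The source may report more compounds than this note shows. Statements on the series, on what has been measured and on what is new or still open speak of the compounds shown alone.

Going by the values given here, compound 2 `Cc1ccccc1-c1ccc(-c2nnc(N(C)Cc3ccc4nccn4c3)o2)cc1` holds the lowest of the two numbers so far: in an assay on isolated protein for inhibition of tyrosine-protein kinase Mer (Homo sapiens), read by LC-MS (on this read-out higher numbers stand for weaker inhibition and lower numbers for stronger inhibition), compound 2 gives 12.6 nM, whereas compound 1 `CN(Cc1ccc2nccn2c1)c1nnc(-c2ccccc2)o1` gives in this assay a value of 15800 nM. Compound 3 `Cc1noc(C)c1-c1ccc(-c2nnc(N(C)Cc3ccc4nccn4c3)o2)cc1` differs from compound 2 by 3,5-dimethyl-1,2-oxazol-4-yl in place of 2-methylphenyl on an aromatic carbon. Among the compounds with values here, the only step that bears on this is a 1300-fold lower number from compound 1 to compound 2 (3.10 log units; beyond the scatter), which shows how much the group at this position matters. Since compound 3 retains a seven-atom aromatic group at the same place, only a modest weakening is expected, a 3.2-fold higher number from compound 2 to compound 3 (0.50 log units; beyond the scatter). Compound 3 is therefore estimated at 40 nM in this assay, with a range of 8 nM to 250 nM.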

Compound 3, half-maximal inhibitory concentration: 200 nM
Compound 3: middle estimate off by 5.0-fold (0.70 log units), on the low side, within the range that was stated.
By their numbers in this assay, from the lowest: compound 2; then compound 3; then compound 1.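

In this assay, two groups of equal heavy-atom count are not interchangeable at this place: 3,5-dimethyl-1,2-oxazol-4-yl in place of 2-methylphenyl gives a clear loss (a 16-fold higher number from compound 2 to compound 3 (1.20 log units; beyond the scatter)). The same group still stands well ahead of hydrogen (a 79-fold lower number from compound 1 to compound 3 (1.90 log units; beyond the scatter)), so a ring of carbon only is not required for a large drop in the number. Nothing at hand explains the gap between the two rings.

Open, from the compounds shown here alone, is whether an unsubstituted phenyl or a pyridine ring would read closer to 2-methylphenyl or to the dimethyl-oxazolyl. Also open, going by these compounds, is how a ring carrying an amine or a carboxylic acid would read here.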